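A few compounds are considered here, and "the series" means these few. Any claim that something is new, unique, unknown or untested is made for them only; others in the source may bear on it.

Measured so far:
compound 1, `O=C(/C(=C/C1CCCCC1)CCl)c1ccccc1` — 22000 nM
compound 2, `CC(=O)OC/C(=C\C1CCCCC1)C(=O)c1ccccc1` — 21000 nM

In a functional assay on HBL-100 cells (Homo sapiens) for inhibition, read by sulforhodamine B assay, with a stated time of 48 h (a higher number here means a weaker inhibitor of growth, a lower number a stronger inhibitor of growth), compound 1 gives 22000 nM and compound 2 gives 21000 nM. The two numbers stand within the scatter of each other; the step of a 1.0-fold lower number from compound 1 to compound 2 (0.02 log units; within the scatter) does not separate them, so compound 2 holds no distinct place among the numbers shown.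

Compound 3, `CCC(/C=C(\COC(C)=O)C(=O)c1ccccc1)CC`, has not yet been measured. It differs from compound 2 by pentan-3-yl in place of cyclohexyl on a double-bonded chain carbon bound to a double-bonded chain carbon. Within the data shown here, the only measured step, a 1.0-fold lower number from compound 1 to compound 2 (0.02 log units; within the scatter), concerns the exchange of chloro for acetoxy on the saturated chain carbon and leaves the cyclohexyl end untouched; no measured pair bears on the present change. With nothing in the data pointing either way, the expected step from compound 2 to compound 3 is a 1.1-fold higher number from compound 2 to compound 3 (0.06 log units; within the scatter), that is, none beyond the scatter. The estimate for compound 3 in this assay is 24000 nM, with a range from 10000 nM to 60000 nM.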

Compound 3, concentration for 50% growth inhibition: > 100000 nM
Compound 3 was reported as a limit; the forecaster's own chance of this, stated with the estimate: 10%; middle value at least 4.1-fold (0.61 log units) away from the limit.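

Among these compounds, replacing cyclohexyl with pentan-3-yl on this double-bonded chain carbon gives an at least 4.7-fold higher number from compound 2 to compound 3 (0.67 log units; beyond the scatter) in this assay, so this place responds to a change that the earlier compounds left untouched. Among the compounds shown here, the only earlier step, at the saturated chain carbon, was a 1.0-fold lower number from compound 1 to compound 2 (0.02 log units; within the scatter) and showed no separation. In this assay compound 3 gives > 100000 nM, which is a limit of the assay and not a number, so the full size of the step stays unknown: the limit of > 100000 nM in this assay, at which 1 of the 3 values shown sits.

The compounds shown leave open whether the ring as such matters at this place, or whether another group, such as cyclopentyl, phenyl or a longer chain like n-hexyl, would keep the level of compound 2. They also leave open whether chloro and acetoxy would still stand within the scatter of each other alongside pentan-3-yl.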